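This account rests on a few compounds, and the source may have more. Where it says the series, first, only, none or still open, it means among the compounds named here.

Compound 1 `Cc1cc(N2CCNC2=O)cc(C)c1CCS(=O)(=O)N1CCC2(CC1)N=C(C1CCCCC1)NC2=O` gives 62 uL/min in an ADME assay on microsomes from liver (Homo sapiens) for metabolic stability, read by LC-MS, using NADPH, with a stated time of 30 min, tested at 1 uM; on this read-out lower numbers stand for slow clearance and higher numbers for fast clearance.
Compound 2 `CC(=O)Nc1ccc(CCS(=O)(=O)N2CCC3(CC2)N=C(C2CCCCC2)NC3=O)c(C)c1` gives 46 uL/min in this assay.

Going by the values given here, of the two numbers measured so far, compound 2 has the lower one, but the gap to compound 1 is within the scatter of repeated measurements, so the two compounds cannot be placed in order on this read-out. Both share the same core and differ only in the substituted aromatic ring at the end of the chain.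

The step from compound 2 to compound 3 `Cc1ccccc1CCS(=O)(=O)N1CCC2(CC1)N=C(C1CCCCC1)NC2=O` is described as follows: hydrogen in place of acetamido on an aromatic carbon. Among the compounds with values here, no measured pair shows the effect of this change, so the expectation rests only on the two values at hand, which are close to one another.

In this assay compound 3 is expected to move by a 1.5-fold higher number from compound 2 to compound 3 (0.18 log units; within the scatter), a shift that would stay close to the scatter and not point clearly in either direction. Compound 3 is therefore estimated at 70 uL/min, with a range from 35 uL/min to 140 uL/min.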

Compound 3, intrinsic clearance in a liver preparation (reported as CLH), per the amount of preparation that the assay uses in the Homo sapiens assay: 100 uL/min
Compound 3: middle estimate off by 1.4-fold (0.15 log units), on the low side; the measured number falls inside the stated range.
By their numbers in the Homo sapiens assay, from the lowest: compounds 2, 1 and 3 (each within the scatter of the next, the first and the last beyond it).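

In the Homo sapiens assay the change from acetamido to hydrogen, on the aromatic carbon para to a large group, comes with a 2.2-fold higher number from compound 2 to compound 3 (0.34 log units; beyond the scatter), the only single-place step shown here and one that lies beyond the scatter, which the close values of the two earlier compounds could not reveal. The same change has a much larger counterpart in a physicochemical assay for solubility, read by HPLC, in phosphate buffer, at pH 6.5, tested at 1 mM (a higher number here means a more soluble compound, a lower number a less soluble compound), where compound 2 gives 280 ug/mL and compound 3 gives 11 ug/mL. At this position, then, the acetamido group carries a modest benefit on the clearance read-out and a large one on solubility, and the loss of solubility on its removal stands as measured: the measured solubility of compound 2, 280 ug/mL, and of compound 3, 11 ug/mL, a 25-fold lower number (1.41 log units; beyond the scatter)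

The compounds shown leave open whether an amine or a carboxylic acid on the same aromatic carbon would hold both read-outs where compound 2 stands, or whether this behaviour belongs to acetamido alone. Compound 1 differs from compound 2 and from compound 3 in more than one place, so the part played by its own ring substituents remains unresolved.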